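The source may report more compounds than this note shows. Statements on the series, on what has been measured and on what is new or still open speak of the compounds shown alone.

Measured compounds:
compound 1, `COC(=O)C1=C(C)N=C(C)/C(=C(\O)OC)C1c1cccc(OC(C)=O)c1`: 6030 nM
compound 2, `COC(=O)C1=C(C)N=C(C)/C(=C(\O)OC)C1c1ccccc1N`: 39800 nM

Both were tested in a functional assay (muscle tissue) with Cavia porcellus as the target; a higher number here means that more compound is needed for the effect, a lower number that less compound is needed. Compound 1 gives 6030 nM, the lower of the two numbers, while compound 2 gives 39800 nM, a higher number whose distance from compound 1 lies beyond the usual scatter; less of compound 1 is needed for the effect. The two compounds differ in more than one place, so their gap is simply noted, not traced to any single change.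

Compound 3, `COC(=O)C1=C(C)N=C(C)/C(=C(\O)OC)C1c1cccc(OC(=O)c2ccccc2)c1`, has not been measured. It differs from compound 1 in one place: phenyl in place of methyl on a carbonyl carbon. Put another way, the acetoxy group of compound 1 becomes a benzoyloxy group, a six-membered aromatic ring of carbon only entering where a methyl stood. Going by the values given here, no measured pair shows what such a change does in this assay, so the expectation rests on compound 1 alone. The expected step is a 1.3-fold higher number from compound 1 to compound 3 (0.12 log units; within the scatter), a small move toward a higher number that may well fall within the scatter. Compound 3 is therefore estimated at 8000 nM, with a range from 2500 nM to 25000 nM.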

Compound 3, half-maximal effective concentration: 6310 nM
Compound 3: middle estimate off by 1.3-fold (0.10 log units), on the high side; low and high end bracket the measured number.
By their numbers in this assay, from the lowest: compounds 1 and 3 (each within the scatter of the next); then compound 2.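

In this assay, putting a phenyl in place of the methyl on the carbonyl carbon gives a 1.0-fold higher number from compound 1 to compound 3 (0.02 log units; within the scatter). Going by these compounds alone, this is the first view of what this place will take: the acetoxy group of compound 1 and the benzoyloxy group of compound 3 cannot be told apart by their numbers, even though a six-membered aromatic ring of carbon stands where a single methyl stood, so in this assay the position tolerates a much larger group on the carbonyl carbon. Nothing at hand says why the two numbers stand so close together.

From the compounds shown here alone, whether this tolerance reaches beyond a plain carbon ring stays open, since a longer chain such as butyl, or a group carrying an amine or a carboxylic acid, could give a very different number at the same carbonyl carbon. Within the data shown here, the gap between compound 1 and compound 2 also remains untraced, as those two differ in more than one place and no single step connects them.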